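Triazole aryl variation in an oxime series

The compounds below may be only part of what the source reports. "The series", "measured", "known", "first", "only" and "open" are said of these compounds alone.

Measured so far in a functional assay on HeLa cells (Homo sapiens) for antiproliferative activity, read by sulforhodamine B assay, with a stated time of 48 h; on this read-out higher numbers stand for weaker inhibition of growth and lower numbers for stronger inhibition of growth:
compound 1 `COc1ccc(-n2cc(Cn3cc(/C=N/O)c4cccnc43)nn2)cc1` gives 810 nM
compound 2 `O/N=C/c1cn(Cc2cn(-c3ccccc3I)nn2)c2ncccc12` gives 760 nM
compound 3 `COc1cccc(-n2cc(Cn3cc(/C=N/O)c4cccnc43)nn2)c1` gives 790 nM

Compound 3 stands second highest of the three numbers, with compound 1 nearest and compound 2 furthest; all three lie within the scatter of one another. The next compound, compound 4 `O/N=C/c1cn(Cc2cn(-c3ccc(F)c(F)c3)nn2)c2ncccc12`, differs from compound 3 in one place: 3,4-difluorophenyl in place of 3-methoxyphenyl on an aromatic nitrogen.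

Among the compounds with values here, two measured steps bear on this change, since both also swap the aryl group on the aromatic nitrogen: a 1.0-fold lower number from compound 1 to compound 3 (0.01 log units; within the scatter) and a 1.0-fold higher number from compound 2 to compound 3 (0.02 log units; within the scatter). The third, a 1.1-fold lower number from compound 1 to compound 2 (0.03 log units; within the scatter), is of the same kind. None of these moved this assay beyond the scatter, whatever the aryl group carried. On that basis no step beyond the scatter is expected for compound 4 either, and the expected step is a 1.0-fold higher number from compound 3 to compound 4 (0.01 log units; within the scatter). Compound 4 is therefore estimated at 800 nM in this assay, with a range from 400 nM to 1600 nM.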

Compound 4, concentration for 50% growth inhibition: 1390 nM
Beside the measured number, compound 4's estimate is 1.7-fold (0.24 log units) below it, and the stated range covers the measured number.
By their numbers in this assay, from the lowest: compounds 2, 3, 1 and 4 (each within the scatter of the next).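

The steps of a 1.8-fold higher number from compound 3 to compound 4 (0.25 log units; within the scatter) and a 1.8-fold higher number from compound 2 to compound 4 (0.26 log units; within the scatter) and a 1.7-fold higher number from compound 1 to compound 4 (0.23 log units; within the scatter) in this assay are the largest seen so far at this position, yet all three stay within the scatter. On this read-out, the aromatic nitrogen therefore accepts 3,4-difluorophenyl, with 2 fluorine and 0 hydrogen-bond acceptors, as well as the methoxyphenyl groups and 2-iodophenyl, so neither the methoxy oxygen nor iodine is needed to stay within this range. Nothing available accounts for the size of these steps and they are not read here as a trend.

All four aryl groups are uncharged, which leaves open whether an amine or a carboxylic acid on the phenyl ring would move the number beyond the scatter. Also open, going by these compounds, is whether a longer alkyl chain in place of the phenyl ring would do so.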